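Chain step from compound 3 to compound 4

The compounds below may be only part of what the source reports. "The series", "measured", "known", "first", "only" and "open" are said of these compounds alone.

Measured in a physicochemical assay for lipophilicity (a lower number here means a more polar compound, a higher number a more lipophilic compound), so far:
- compound 1 `CCCCCOC(=O)c1ccc(S(N)(=O)=O)cc1` gives 2.71
- compound 2 `CCCCCCOC(=O)c1ccc(S(N)(=O)=O)cc1` gives 3.23
- compound 3 `CCCOC(=O)c1ccccc1S(N)(=O)=O` gives 1.49

Compound 3 at 1.49 stands lowest of the three, beyond the scatter from both others. Compound 4 `CCCCOC(=O)c1ccccc1S(N)(=O)=O` follows from compound 3 by one change, methyl in place of hydrogen on a saturated chain carbon, three bonds along the chain from an oxygen next to a carbonyl group in the form of propyl to butyl. Among the measured compounds shown here, the one measured step of this kind is a number 0.52 log units higher from compound 1 to compound 2 (beyond the scatter) with methyl in place of hydrogen five bonds along the chain, not three. A rise of similar modest size is expected, estimated as a number 0.51 log units higher from compound 3 to compound 4 (beyond the scatter) in this assay on that single precedent. Compound 4 is estimated at 2 with an expected range from 1.75 to 2.3 for now.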

Compound 4, partition coefficient: 2.01
The estimate for compound 4 lay 0.01 log units below the measured number; measured number inside the range.
By their numbers in this assay, from the lowest: compound 3; then compound 4; then compound 1; then compound 2.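

In this assay, propyl to butyl, three bonds along the chain from an oxygen next to a carbonyl group, gives a number 0.52 log units higher from compound 3 to compound 4 (beyond the scatter) on the core of compound 3. This step has the same size as a number 0.52 log units higher from compound 1 to compound 2 (beyond the scatter), where the same methyl in place of hydrogen stands five bonds along the chain on a different core.

Still open, from the compounds shown here alone, is whether a step of this size holds for a longer chain on the core of compound 3, or what an amine in place of the chain would give. Nothing available explains the size of either step.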